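Lengthening a Chain on Two Different Linkers

The compounds below may be only part of what the source reports. "The series", "measured", "known", "first", "only" and "open" are said of these compounds alone.

Three compounds built on one shared core were measured in a functional assay on NCI-H1299 cells (Homo sapiens) for inhibition, read by CCK-8 assay, with a stated time of 72 h, tested at 10 uM; on this read-out lower numbers stand for a weaker effect and higher numbers for a stronger effect at the one concentration tested. Compound 1 `CN(C)C(=O)c1cc2cnc(Nc3ccc(S(=O)(=O)NCCCCCCN=C=S)cc3)nc2n1C1CCCC1` gives 70.6%. Compound 2 `CN(C)C(=O)c1cc2cnc(Nc3ccc(S(=O)(=O)NCCCCCCCN=C=S)cc3)nc2n1C1CCCC1` gives 83%; the change a group of 4 heavy atoms (2 carbon, 1 nitrogen, 1 sulfur; no ring) in place of a group of 3 heavy atoms (1 carbon, 1 nitrogen, 1 sulfur; no ring), on a saturated chain carbon, six bonds along the chain from a sulfonamide nitrogen made a number 12.4 percentage points higher from compound 1 to compound 2 (beyond the scatter). Compound 3 `CN(C)C(=O)c1cc2cnc(Nc3ccc(NC(=O)CCCN=C=S)cc3)nc2n1C1CCCC1` gives 78.8%; the difference between the cores of compound 1 and compound 3 is not broken down here. Compound 4 `CN(C)C(=O)c1cc2cnc(Nc3ccc(NC(=O)CCCCN=C=S)cc3)nc2n1C1CCCC1` has not yet been measured. It carries the same kind of change, (a group of 4 heavy atoms (2 carbon, 1 nitrogen, 1 sulfur; no ring) in place of a group of 3 heavy atoms (1 carbon, 1 nitrogen, 1 sulfur; no ring), on a saturated chain carbon, three bonds along the chain from a carbonyl carbon), but the surroundings differ: in compound 2 the change sits six bonds along the chain from a sulfonamide nitrogen, in compound 4 three bonds along the chain from a carbonyl carbon. Compound 4 is expected to show a number 7.2 percentage points higher from compound 3 to compound 4 (within the scatter) in this assay, a somewhat smaller step than the earlier one, because a number 12.4 percentage points higher from compound 1 to compound 2 (beyond the scatter) is a single precedent on a different linker and compound 3 already starts from 78.8%. The estimate for compound 4 is 86%, between 74% and 95%.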

Compound 4, a percentage reported as inhibition, at one concentration (the size of the read-out at that concentration, not a potency): 82.5%
Estimate against measurement, compound 4: 3.5 percentage points above; low and high end bracket the measured number.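

On the amide linker, the same change reads as a number 3.7 percentage points higher from compound 3 to compound 4 (within the scatter) in this assay. Set beside the step on the sulfonamide linker, it does not differ: the same change on two cores in this assay, a number 12.4 percentage points higher (beyond the scatter) from compound 1 to compound 2 and a number 3.7 percentage points higher (within the scatter) from compound 3 to compound 4, 8.7 percentage points apart, within the scatter of two such steps. This shows that the change carries to the core of compound 3 without a measurably different outcome, but with one pair on each linker it does not show that the step beyond the scatter on the sulfonamide linker recurs on the amide linker.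

The compounds shown leave open how a longer chain would read on either linker. They also leave open whether an amine or a carboxylic acid at the chain end, in place of the isothiocyanate, would hold these values.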